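The source may report more compounds than this note shows. Statements on the series, on what has been measured and on what is new or still open speak of the compounds shown alone.

Values measured in an ADME assay on HEL cells (Homo sapiens) for cytotoxicity, with a stated time of 3 days; a lower number here means that less compound is tolerated, a higher number that more compound is tolerated:

Compound 1 `Cc1cc(-c2cccc(F)c2)c2ncc(CSCCc3ccccc3)n2c1`: 35 ug/mL
Compound 2 `Cc1cc(-c2ccc(O)cc2)cn2c(CSCCc3ccccc3)cnc12`: > 50 ug/mL, a limit
Compound 3 `Cc1cc(-c2ccsc2)cn2c(CSCCc3ccccc3)cnc12`: > 50 ug/mL, a limit

Compound 3 stands at a limit, > 50 ug/mL, and not at a number. Compound 2 shares that limit, so the series mostly shows (the limit of > 50 ug/mL in this assay, at which 2 of the 3 values shown sit).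

Compound 4 `Cc1cc(I)cn2c(CSCCc3ccccc3)cnc12` differs from compound 3 by one change on an aromatic carbon: iodo in place of thiophen-3-yl on an aromatic carbon.

Among the compounds with values here, only one measured step touches that same carbon, a step that the two limits leave unreadable from compound 2 to compound 3. It offers no size to carry over. Compound 1 gives the only true number, 35 ug/mL, which shows that a readable value can occur among these compounds. In this assay, the expectation is therefore a small move toward less compound tolerated, or none beyond the scatter. The expected change is an at least 1.1-fold lower number from compound 3 to compound 4 (0.04 log units; that floor lies within the scatter). For compound 4 the estimated value is 45 ug/mL, with an expected range from 20 ug/mL to 80 ug/mL.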

Compound 4, half-maximal cytotoxic concentration: > 50 ug/mL
Compound 4 gave a limit, no number (the forecaster's own chance of this, stated with the estimate: 50%); at least 1.1-fold (0.04 log units) between middle value and limit.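

In this assay, within the data shown here, compound 2, compound 3 and compound 4 all give limits rather than numbers, so no step among them can be read. The compounds shown leave open whether 4-hydroxyphenyl, thiophen-3-yl or iodo on that aromatic carbon differ at all: the limit of > 50 ug/mL in this assay, at which 3 of the 4 values shown sit.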